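A few compounds are considered here, and "the series" means these few. Any claim that something is new, unique, unknown or untested is made for them only; others in the source may bear on it.

Of the compounds shown here, two on a shared core have so far been measured in a functional assay on PC-3 cells (Homo sapiens) for cytotoxicity, read by MTT assay, with a stated time of 48 h; a higher number here means a weaker inhibitor, a lower number a stronger inhibitor. Compound 1 `CC1=NN(C(=O)c2ccccc2C)C(c2ccccc2O)C1` gives 106000 nM. Compound 2 `CC1=NN(S(=O)(=O)c2ccccc2)C(c2ccccc2O)C1` gives 50600 nM, the lower of the two numbers and so the stronger result, with a gap to compound 1 that lies beyond the usual scatter of repeated measurements. Both values sit high on the scale, so compound 2 is the better of two weak inhibitors.

The next compound, compound 3 `CC1=NN(S(=O)(=O)c2ccc(C)cc2)C(c2ccccc2O)C1`, departs from compound 2 by a single small change: methyl in place of hydrogen on an aromatic carbon, para to a large group. Among the measured compounds shown here, no measured pair here shows what this change does in this assay, so the data give no direction for it. A shift within the scatter is therefore the expectation, and the anchor is compound 2 at 50600 nM. The estimated change, a 1.1-fold lower number from compound 2 to compound 3 (0.05 log units; within the scatter), is expected to be no larger than the scatter. For compound 3 the expected value is 45000 nM, with an estimated range from 20000 nM to 100000 nM.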

Compound 3, half-maximal inhibitory concentration: 85500 nM
Beside the measured number, compound 3's estimate is 1.9-fold (0.28 log units) below it; low and high end bracket the measured number.
By their numbers in this assay, from the lowest: compounds 2, 3 and 1 (each within the scatter of the next, the first and the last beyond it).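

Among the compounds shown here, this is the first reading of methyl in place of hydrogen on an aromatic carbon, para to a large group, and in this assay it amounts to a 1.7-fold higher number from compound 2 to compound 3 (0.23 log units; within the scatter), so the change from phenyl to 4-methylphenyl does not separate the two compounds. The opening pair could say nothing about this position, whereas this step shows that a single added methyl here leaves the result in the same weak range, with compound 3 at 85500 nM. No measurement at hand speaks to what lies behind this step.

The compounds shown leave open what a chlorine atom, a methoxy group, an amine or a carboxylic acid would do at the same place, para to a large group, and whether any of them would move the number in this assay beyond the scatter. They also leave open whether a methyl group would give a similarly small step at another carbon of this ring, since this single pair covers only one position and one small group.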